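Phenoxy for phenyl on the chain of compound 1

The source may hold more compounds than are shown below. What is called first, only, known or untested is meant among the compounds shown, and "the series" means these compounds.

Measured so far in an in vitro functional assay on HEK ts201 cells for antagonist activity at Neuronal acetylcholine receptor; alpha4/beta2 (Homo sapiens), read by fluorescence and calcium flux; a lower number here means a stronger inhibitor, a higher number a weaker inhibitor:
compound 1 `CC1CC(=O)N(c2ccccc2C(=O)OCC2CCCN(CCCCCc3ccccc3)C2)C1=O` — 24500 nM
compound 2 `O=C(Nc1ccccc1)c1ccccc1-c1ccccc1` — 6900 nM
compound 3 `O=C(OCC1CCCN(CCCc2ccccc2)C1)c1ccccc1N1C(=O)c2ccccc2C1=O` — 5010 nM

Compound 1 gives the highest number of the three; its gaps to compound 2 and to compound 3 are both beyond the scatter, so compound 1 is the weakest inhibitor in this set, while the values of compound 2 and compound 3 lie within the scatter of each other. No pair of these compounds differs in a single place, so no single-point step can be read from them. Compound 4 `CC1CC(=O)N(c2ccccc2C(=O)OCC2CCCN(CCCCCOc3ccccc3)C2)C1=O` is not yet measured; it differs from compound 1 by phenoxy in place of phenyl on a saturated chain carbon, five bonds along the chain from an amine nitrogen in a ring. The measured set holds nothing bearing on this exchange. For compound 4 the expected step is a 1.2-fold lower number from compound 1 to compound 4 (0.09 log units; within the scatter), that is, none beyond the scatter. Compound 4 is thus estimated at 20000 nM, in a range from 7000 nM to 55000 nM.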

Compound 4, half-maximal inhibitory concentration: 17000 nM
Compound 4: the middle estimate sits 1.2-fold (0.07 log units) above what was measured; low and high end bracket the measured number.
By their numbers in this assay, from the lowest: compounds 3 and 2 (each within the scatter of the next); then compounds 4 and 1 (each within the scatter of the next).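

In this assay, phenoxy in place of phenyl on a saturated chain carbon, five bonds along the chain from an amine nitrogen in a ring, gives a 1.4-fold lower number from compound 1 to compound 4 (0.16 log units; within the scatter). On this core, then, the position accepts the extra oxygen and its hydrogen-bond acceptor with the two values staying within the scatter of each other. Nothing measured here bears on the reason for this result.

Still open, going by these compounds, is whether an amine or a carboxylic acid at the chain end would give a step beyond the scatter. The effect of a shorter phenoxyalkyl chain on this core also remains unresolved.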